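The compounds below may be only part of what the source reports. "The series", "measured", "known", "first", "only" and "open" are said of these compounds alone.

Measured in a physicochemical assay for solubility, read by HPLC, in phosphate buffer, measured as kinetic solubility, at pH 7.4; on this read-out lower numbers stand for lower solubility and higher numbers for higher solubility:
- Compound 1 `CCC(=O)c1cc(-c2ccccc2)n(-c2ccc(S(N)(=O)=O)cc2)c1C`: 14100 nM
- Compound 2 `CCC(=O)c1cc(-c2ccc(C)cc2)n(-c2ccc(S(N)(=O)=O)cc2)c1C`: 1000 nM

Compound 2 stands lower of the two, at 1000 nM. Compound 3 `CCC(=O)c1cc(-c2cccc(Cl)c2)n(-c2ccc(S(N)(=O)=O)cc2)c1C` has 3-chlorophenyl in place of 4-methylphenyl on an aromatic carbon. Going by the values given here, only one measured step bears on this, and only loosely: a 14-fold lower number from compound 1 to compound 2 (1.15 log units; beyond the scatter), where methyl took the place of hydrogen on an aromatic carbon. Among the compounds with values here, compound 3 keeps a substituted phenyl, as compound 2 does, and no measured pair shows this exact swap. A large change in this assay is therefore not expected. The expected step is a 1.5-fold higher number from compound 2 to compound 3 (0.18 log units; within the scatter), which means no clear change beyond the scatter. The estimated value for compound 3 is 1500 nM, with an expected range of 450 nM to 5000 nM.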

Compound 3, solubility: 12600 nM
Compound 3: the middle estimate sits 8.4-fold (0.92 log units) below what was measured, and the stated range ends below it.
By their numbers in this assay, from the lowest: compound 2; then compounds 3 and 1 (each within the scatter of the next).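

The 3-chlorophenyl group in place of 4-methylphenyl gives a 13-fold higher number from compound 2 to compound 3 (1.10 log units; beyond the scatter), and chloro in place of hydrogen gives a 1.1-fold lower number from compound 1 to compound 3 (0.05 log units; within the scatter). So in this assay, a group added to this phenyl ring does not always bring a low number: compound 2 carries one and reads low, while compound 3 carries one and does not. Nothing available explains the difference between the methyl and chloro compounds. As far as these compounds go, it remains open whether the gap follows from the kind of group or from its place on the ring, and whether a methoxy group or an amine there would read like compound 2 or like compound 3.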